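Moving a Methyl Group Around a Phenyl Ring

The source may report more compounds than this note shows. Statements on the series, on what has been measured and on what is new or still open speak of the compounds shown alone.

Compound 1 `Clc1ccc(-c2cc(-c3ccoc3)cc(-c3ccco3)n2)s1` and compound 2 `Cc1ccccc1-c1cc(-c2ccoc2)cc(-c2ccc(Cl)s2)n1` share one core. In an assay on isolated protein for inhibition of DNA topoisomerase 1 (Homo sapiens), with a stated time of 30 min, tested at 100 uM (a higher number here means more inhibition at the concentration tested (going by the name of the read-out), a lower number less inhibition), compound 1 gives 9.6% and compound 2 gives 4.6%. Compound 2 stands alongside compound 1 on the numbers shown, since a number 5 percentage points lower from compound 1 to compound 2 (within the scatter) lies within the scatter. Compound 3 `Cc1ccc(-c2cc(-c3ccoc3)cc(-c3ccc(Cl)s3)n2)cc1` differs from compound 2 in one place: 4-methylphenyl in place of 2-methylphenyl on an aromatic carbon. For the measured compounds named here, no measured step alters a methylphenyl group in this way, so nothing bears directly on it, and both measured numbers are small; no step beyond the scatter is expected in this assay. Compound 3 is expected to give 6%, within -4% to 16%. The expected step of a number 1.4 percentage points higher from compound 2 to compound 3 (within the scatter) is estimated to stay within the scatter.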

Compound 3, a percentage reported as inhibition, at one concentration (the size of the read-out at that concentration, not a potency): 0%
The estimate for compound 3 lay 6 percentage points above the measured number; the measured number falls inside the stated range.
By their numbers in this assay, from the lowest: compounds 3, 2 and 1 (each within the scatter of the next).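

With 4-methylphenyl in place of 2-methylphenyl, the assay shows a number 4.6 percentage points lower from compound 2 to compound 3 (within the scatter), so in this assay the place of the methyl group on this phenyl ring does not separate these two compounds. With 4-methylphenyl in place of furan-2-yl, it shows a number 9.6 percentage points lower from compound 1 to compound 3 (within the scatter), so a methylphenyl group and a furan-2-yl group at this carbon next to the ring nitrogen are not told apart either. No evidence is at hand that explains these numbers.

Still open, as far as these compounds go, is whether 3-methylphenyl would read the same. Also open, from the compounds shown here alone, is whether a group of another kind at this carbon, such as an amine or a carboxylic acid, would give a step beyond the scatter.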